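The compounds below may be only part of what the source reports. "The series", "measured", "known", "first", "only" and "open" are said of these compounds alone.

Compound 1 `COc1ccc(-c2cn(C[C@H]3c4c(ccc(O)c4C)[C@@H]4CC[C@@]5(C)C[C@]43CC5=O)nn2)cc1` was tested in a functional assay on HL-60 cells (Homo sapiens) for cytotoxicity, read by MTT assay, with a stated time of 4 days; on this read-out higher numbers stand for weaker inhibition and lower numbers for stronger inhibition. In this assay compound 1 gives > 20000 nM, which is a limit of the assay rather than a measured number. Two related compounds were run in the same way. Compound 2 `C=C1C[C@]23C[C@@]1(O)CC[C@H]2c1cc(Br)c(O)c(C)c1[C@@H]3Cn1cc(-c2ccccn2)nn1` gives > 20000 nM in this assay, again a limit and not a number. Compound 3 `C=C1C[C@]23C[C@@]1(O)CC[C@@H]2c1cccc(C)c1[C@@H]3Cn1cc(-c2ccc(OC)cc2)nn1` gives > 20000 nM in this assay, likewise a limit. All three readings therefore share (the limit of > 20000 nM in this assay, at which 3 of the 3 values shown sit), so none of these compounds can be called stronger or weaker than another, and no step between measured compounds can be drawn from them.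

Compound 4 `Cc1c(O)ccc2c1[C@H](Cn1cc(-c3ccccn3)nn1)[C@@]13CC(=O)[C@@](C)(CC[C@@H]21)C3` has not yet been measured. It is related to compound 1 by a single change: pyridin-2-yl in place of 4-methoxyphenyl on an aromatic carbon. Compound 2 also carries a pyridin-2-yl group on its triazole, and its value and that of compound 1 both rest at the limit, which is all the two readings show. On this basis the step from compound 1 to compound 4 is expected to be none beyond the usual scatter, a number no higher from compound 1 to compound 4 (the limit leaves the size open). Compound 4 is accordingly estimated to give 20000 nM in this assay, most probably reported once more only as a limit, with a plausible range from 7000 nM to 20000 nM.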

Compound 4, half-maximal inhibitory concentration: > 20000 nM
Compound 4: no number, only a limit (the forecaster's own chance of this, stated with the estimate: 75%); the middle value lies on the limit itself.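

In this assay compound 4 gives > 20000 nM, which is a limit of the assay and not a number. No step from compound 1 to compound 4 can be read, because both compounds rest at the same limit: the limit of > 20000 nM in this assay, at which 4 of the 4 values shown sit.

The compounds shown leave open whether pyridin-2-yl in place of 4-methoxyphenyl changes cytotoxicity at all.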